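Swapping an Ether Chain for an Alkene Chain on Compound 3

The source may report more compounds than this note shows. Statements on the series, on what has been measured and on what is new or still open speak of the compounds shown alone.

Compound 3 `COc1cc(Cc2nc3c(N)ncnc3n2CCOC(C)C)cc(OC)c1OC` gives 38900 nM in a functional assay on MCF7 cells (Homo sapiens) for antiproliferative activity (a higher number here means a weaker inhibitor, a lower number a stronger inhibitor), the second highest of three numbers; compound 2 `C=CCCCn1c(Cc2cc(OC)c(OC)c(OC)c2)nc2c(N)nc(F)nc21` gives 44700 nM, within the scatter of compound 3, while compound 1 `COc1cc(Cc2nc3c(N)nc(F)nc3n2CCOC(C)C)cc(OC)c1OC` gives 15800 nM, the lowest of the three. Compound 4 `CC/C=C\Cn1c(Cc2cc(OC)c(OC)c(OC)c2)nc2c(N)ncnc21` differs from compound 3 by but-1-en-1-yl in place of isopropoxymethyl on a saturated chain carbon bound to an aromatic nitrogen. Going by the values given here, one measured step bears on this: a 2.8-fold higher number from compound 1 to compound 2 (0.45 log units; beyond the scatter), the same kind of exchange of an ether chain for an alkene chain on the core of compound 1. Among the compounds with values here, the step of a 2.5-fold higher number from compound 1 to compound 3 (0.39 log units; beyond the scatter) shows only that the core of compound 3 sits higher. Compound 4 is therefore expected to sit a modest step higher, a 2.3-fold higher number from compound 3 to compound 4 (0.36 log units; beyond the scatter). Compound 4 is expected to give 90000 nM, with a range from 35000 nM to 250000 nM.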

Compound 4, half-maximal inhibitory concentration: 64600 nM
Compound 4: the middle estimate sits 1.4-fold (0.14 log units) above what was measured; low and high end bracket the measured number.
By their numbers in this assay, from the lowest: compound 1; then compounds 3, 2 and 4 (each within the scatter of the next).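

In this assay, the step of a 1.7-fold higher number from compound 3 to compound 4 (0.22 log units; within the scatter) lies within the scatter, so on this core, which lacks the fluoro group, but-1-en-1-yl and isopropoxymethyl cannot be told apart at this saturated chain carbon bound to an aromatic nitrogen. The related exchange on the fluoro-bearing core, a 2.8-fold higher number from compound 1 to compound 2 (0.45 log units; beyond the scatter) in the same assay, lies beyond the scatter, so an ether chain and an alkene chain do not read alike on the two cores. As far as these compounds go, whether a chain ending in an amine or a carboxylic acid would shift the number on either core stays open. Nothing available explains the difference between the two cores.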